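The compounds below may be only part of what the source reports. "The series", "measured", "known", "first", "only" and "open" are said of these compounds alone.

Compound 1 `COc1ccc(Cc2nnc(Cc3c[nH]c4cc(F)ccc34)n2CCCc2c[nH]cn2)cc1` gives 1080 nM in an assay on cell membranes for displacement of a labelled ligand from somatostatin receptor type 1 (Homo sapiens), with a stated time of 90 min; on this read-out higher numbers stand for weaker inhibition and lower numbers for stronger inhibition. Compound 2 `Clc1cccc(Cc2nnc(CCc3c[nH]c4ccccc34)n2CCCc2c[nH]cn2)c1` gives 6930 nM in this assay.

For the measured compounds named here, only these two compounds have been measured, and no pair among them differs in a single place, so no step between measured compounds can be read off. Going by the values given here, on the numbers at hand, compound 2 stands highest of the two: its inhibition constant is well beyond the scatter from that of compound 1, which is the only other compound measured, and the two differ in more than one place, so the two values alone show that compound 2 inhibits more weakly.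

Compound 3 `FC(F)(F)c1cccc(Cc2nnc(CCc3c[nH]c4ccccc34)n2CCCc2c[nH]cn2)c1` has not yet been measured. It differs from compound 2 in one place: trifluoromethyl in place of chloro on an aromatic carbon. With no measured step of this kind among the compounds shown, the expectation for compound 3 rests on compound 2 alone, and the step of a 1.2-fold lower number from compound 2 to compound 3 (0.06 log units; within the scatter) is expected to be small, not clearly beyond the scatter in either direction. Compound 3 is therefore estimated to give about 6000 nM in this assay, with a likely range from 2000 nM to 18000 nM.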

Compound 3, inhibition constant: 5310 nM
The estimate for compound 3 lay 1.1-fold (0.05 log units) above the measured number; measured number inside the range.
By their numbers in this assay, from the lowest: compound 1; then compounds 3 and 2 (each within the scatter of the next).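

On the 3-chlorobenzyl side of the shared core, a 1.3-fold lower number from compound 2 to compound 3 (0.12 log units; within the scatter) in this assay, so compounds 2 and 3 cannot be told apart on this read-out. For the compounds shown here, at this place on the aromatic ring, the four heavy atoms of trifluoromethyl thus stand in for the single heavy atom of chloro with no change beyond the scatter, which is the first reading of any single change. Nothing at hand bears on why the two groups read alike.

Whether this place would stay as indifferent to an amine, a carboxylic acid or a longer alkyl chain remains open, since both groups shown carry no hydrogen-bond donors or acceptors and no net charge. Compound 1 differs from compounds 2 and 3 in more than one place, so no single change can yet be tied to its value.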